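Swapping Phenethyl for 4-Fluorophenyl on a Sulfur

The source may report more compounds than this note shows. Statements on the series, on what has been measured and on what is new or still open speak of the compounds shown alone.

In a functional assay on A-375 cells (Homo sapiens) for inhibition, read by CCK-8 assay, with a stated time of 72 h, tested at 8 uM (a higher number here means more inhibition of growth at the concentration tested, a lower number less inhibition of growth), compound 2 (`Nc1ccccc1NC(=O)c1ccc(CSCCc2ccccc2)cc1`) gives 69.9% and compound 1 (`CCc1ccc(SCc2ccc(C(=O)Nc3ccccc3N)cc2)cc1`) gives 71.1% so the two sit within the scatter of each other. Compound 3 (`Nc1ccccc1NC(=O)c1ccc(CSc2ccc(F)cc2)cc1`) carries 4-fluorophenyl in place of phenethyl on a sulfur. Going by the values given here, the one measured step at this same place is the change to phenethyl from 4-ethylphenyl (a number 1.2 percentage points lower from compound 1 to compound 2 (within the scatter)) and it stays within the scatter. No change beyond the scatter is therefore expected in this assay for this new swap. The expected step is small (a number 3.9 percentage points lower from compound 2 to compound 3 (within the scatter)). Compound 3 is estimated to give 66% (expected range 52% to 79%).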

Compound 3, percent growth inhibition at one concentration: 54.3%
Beside the measured number, compound 3's estimate is 11.7 percentage points above it, within the range that was stated.
By their numbers in this assay, from the lowest: compound 3; then compounds 2 and 1 (each within the scatter of the next).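

The group on this sulfur does matter in this assay: phenethyl and 4-ethylphenyl read alike, yet 4-fluorophenyl in place of phenethyl gives a number 15.6 percentage points lower from compound 2 to compound 3 (beyond the scatter) and so falls beyond the scatter. Between the two aryl groups, fluoro in place of ethyl on an aromatic carbon gives a number 16.8 percentage points lower from compound 1 to compound 3 (beyond the scatter) as well, so one change on that ring is enough to shift the reading. Nothing available here explains either step. Still open, on these data alone, is whether plain phenyl or 4-aminophenyl on this sulfur would read nearer compound 3 or compound 1.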